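Replacing 4-methylphenyl with hydrogen on a weak compound

The source may hold more compounds than are shown below. What is called first, only, known or untested is meant among the compounds shown, and "the series" means these compounds.

In a functional assay on A-375 cells (Homo sapiens) for antiproliferative activity, read by MTT assay, with a stated time of 72 h (on this read-out lower numbers stand for stronger inhibition and higher numbers for weaker inhibition), compound 1 (`O=C1COc2ccc(-c3cccc(NS(=O)(=O)c4ccc(F)cc4)c3)cc2N1c1ccc(Cl)cc1`) gives 32500 nM, and compound 3 (`O=C1COc2ccc(-c3cnc(Cl)c(NS(=O)(=O)c4ccc(F)cc4)c3)cc2N1c1ccccc1`) gives 36900 nM. Compound 2 (`Cc1ccc(N2C(=O)COc3ccc(-c4cnc5ccccc5c4)cc32)cc1`) reaches only a limit of the assay, > 40000 nM, and has no exact number. Compound 4 (`O=C1COc2ccc(-c3cnc4ccccc4c3)cc2N1`) carries hydrogen in place of 4-methylphenyl on an amide-type nitrogen in a ring, a change counted as hydrogen in place of 4-methylphenyl on an amide-type nitrogen in a ring. Among the measured compounds shown here, no measured pair of compounds tests this change, so the expectation in this assay is for no step beyond the usual scatter. The estimated step that the limit leaves unreadable from compound 2 to compound 4 is accordingly small. For compound 4 the expected value is 45000 nM, with an estimated range of 20000 nM to 90000 nM.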

Compound 4, half-maximal inhibitory concentration: > 40000 nM
Compound 4 gave a limit, no number; the forecaster's own chance of this, stated with the estimate: 65%; the middle value lies beyond the limit too.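

Compound 2 and compound 4 both end at a limit of the assay, so no step can be read between them: the limit of > 40000 nM in this assay, at which 2 of the 4 values shown sit.

The compounds shown leave open whether hydrogen in place of 4-methylphenyl on an amide-type nitrogen in a ring shifts the read-out at all.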